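Fluoro for Acetyl: Expecting Compound 4

The compounds below may be only part of what the source reports. "The series", "measured", "known", "first", "only" and "open" are said of these compounds alone.

Of the compounds shown here, three have been measured in an ADME assay on the whole organism with Oryza sativa as the target, tested at 0.1 uM; a higher number here means a weaker effect of the compound at the concentration tested, a lower number a stronger effect. Compound 1 `CC(=O)c1ccccc1NC(=O)N[C@@H](C)c1ccccc1` gives 100%. Compound 2 `CC(=O)c1cccc(NC(=O)N[C@H](C)c2ccccc2)c1` is built from the same atoms joined differently; the difference between the two cores is not broken down here. In this assay compound 2 gives 98%. Compound 3 `C[C@H](NC(=O)Nc1ccccc1F)c1ccccc1` differs from compound 1 by fluoro in place of acetyl on an aromatic carbon, and in this assay compound 3 gives 98%. That change produced a number 2 percentage points lower from compound 1 to compound 3 (within the scatter). Compound 2 and compound 3 stand level at the digits reported, and all three numbers lie within the usual scatter of one another, so none of them can be called stronger or weaker than the others.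

Compound 4 `C[C@@H](NC(=O)Nc1cccc(F)c1)c1ccccc1` remains to be measured. It differs from compound 2 by fluoro in place of acetyl on an aromatic carbon. Among the compounds with values here, this is the same kind of change as the one from compound 1 to compound 3, but not the same: in compound 3 the fluoro stands ortho to a large group, whereas in compound 4 it stands meta to a large group. Because the earlier instance gave a number 2 percentage points lower from compound 1 to compound 3 (within the scatter), and because compound 2 already gives 98%, the step from compound 2 to compound 4 is expected to be a number 1 percentage points lower from compound 2 to compound 4 (within the scatter) in this assay. Compound 4 is accordingly estimated at 97% in this assay, with an expected range from 88% to 100%.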

Compound 4, a percentage reported as activity, at one concentration (the size of the read-out at that concentration, not a potency): 99%
Compound 4: middle estimate off by 2 percentage points, on the low side; the measured number falls inside the stated range.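

In this assay, fluoro in place of acetyl on an aromatic carbon, here meta to a large group, gives a number 1 percentage points higher from compound 2 to compound 4 (within the scatter). Set beside the earlier instance of the same change, the new step does not show that the core matters, and the two steps agree as far as the scatter allows: the same change on two cores in this assay, a number 2 percentage points lower (within the scatter) from compound 1 to compound 3 and a number 1 percentage points higher (within the scatter) from compound 2 to compound 4, 3 percentage points apart, within the scatter of two such steps What this shows is limited to these two pairs: on both cores the change leaves the read-out within the scatter, so no measurable effect of the change is seen here, and the agreement is one between two steps that cannot be told from no change at all, not evidence that a real effect carries from one core to another.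

On these data alone, it remains open whether the change would behave alike on a core whose number lies well away from those of these four compounds, where a step beyond the scatter could be seen at all. The compounds shown also leave open whether another group on the same aromatic ring, such as an amine, a carboxylic acid or a nitrile, would give a number that stands apart from those of acetyl and fluoro.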